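Replacing a methyl on the saturated ring with a heteroaromatic group

This account rests on a few compounds, and the source may have more. Where it says the series, first, only, none or still open, it means among the compounds named here.

Measured compounds:
- compound 1, `CC1CCN(c2nc(-c3ccccc3)nc3ccccc23)CC1`: 69%
- compound 2, `CC1CCN(c2nc(-c3ccc(Cl)cc3)nc3ccccc23)CC1`: 55.1%

In a functional assay on the whole organism for inhibition, with Rattus norvegicus as the target, read by paw edema, with stated times of 4 days, 1 h and 2 h, at a dose of 100 mg/kg by the oral route (a higher number here means more inhibition at the dose given (going by the name of the read-out), a lower number less inhibition), compound 1 gives 69%, the highest of the two numbers shown; the nearest is compound 2, which gives 55.1%. For the measured compounds named here, the one measured step, a number 13.9 percentage points lower from compound 1 to compound 2 (beyond the scatter), concerns a substituent on the aromatic ring and therefore does not touch the position that changes here.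

Compound 3, `O=c1[nH]nc(C2CCN(c3nc(-c4ccccc4)nc4ccccc34)CC2)s1`, is not yet measured. It differs from compound 1 as follows: a group of 6 heavy atoms (2 carbon, 2 nitrogen, 1 oxygen, 1 sulfur; one five-membered aromatic ring with 3 hetero atoms) in place of one carbon atom, on a saturated ring carbon. Going by the values given here, no measured step involves the saturated ring carbon or a group of this kind, so the direction of the change is not settled by the data, and the step from compound 1 is expected to be of modest size rather than large. Compound 3 is therefore estimated at 60%, with a range from 35% to 80%, meaning an expected step of a number 9 percentage points lower from compound 1 to compound 3 (within the scatter).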

Compound 3, a percentage reported as inhibition, in the whole organism at one dose (the size of the read-out at that dose, not a potency): 12.7%
Compound 3: middle estimate off by 47.3 percentage points, on the high side; measured number below the stated range.
By their numbers in this assay, from the lowest: compound 3; then compound 2; then compound 1.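

In this assay the saturated ring carbon proves to be a position where the group carried matters greatly: the five-membered aromatic ring with 3 hetero atoms in place of methyl brings a number 56.3 percentage points lower from compound 1 to compound 3 (beyond the scatter) and so a large step. For the compounds shown here, the only earlier step, a number 13.9 percentage points lower from compound 1 to compound 2 (beyond the scatter) and thus modest, concerned chloro on an aromatic carbon and left methyl in place on this ring in both compounds, so it could say nothing about this position. The data at hand offer no explanation for the loss at this position.

With a single replacement shown at this carbon, it remains open whether the loss belongs to this particular heteroaromatic ring or would follow from other groups in place of methyl. An ethyl, an amine or a carboxylic acid on the same carbon would help to separate these possibilities.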